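This account rests on a few compounds, and the source may have more. Where it says the series, first, only, none or still open, it means among the compounds named here.

Compound 1 `C=CC(=O)Nc1cccc(Nc2nc(N/N=C/c3ccccc3F)ncc2Cl)c1` is the starting point of this comparison. In an ADME assay on HT-29 cells (Homo sapiens) for inhibition, read by MTT assay, with a stated time of 72 h (a higher number here means a weaker inhibitor, a lower number a stronger inhibitor), compound 1 gives 3500 nM, the lowest of the three numbers measured, though its two neighbours sit within the scatter of it. Compound 2 `C=CC(=O)Nc1cccc(Nc2nc(N/N=C/c3ccc(F)cc3F)ncc2Cl)c1` gives 4760 nM in this assay, and compound 3 `C=CC(=O)Nc1cccc(Nc2nc(N/N=C(\C)c3ccc(F)cc3)ncc2Cl)c1` gives 5050 nM. The measured steps are small: a 1.4-fold higher number from compound 1 to compound 2 (0.13 log units; within the scatter), a 1.4-fold higher number from compound 1 to compound 3 (0.16 log units; within the scatter) and a 1.1-fold higher number from compound 2 to compound 3 (0.03 log units; within the scatter). All three changes sit on the hydrazone side of the shared core, on an aromatic carbon or on a nitrogen on an aromatic ring, and none of them moved the number beyond the scatter.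

Compound 4 `CN(C)C/C=C/C(=O)Nc1cccc(Nc2nc(N/N=C/c3ccccc3F)ncc2Cl)c1` differs from compound 1 on the other end of the molecule: 3-(dimethylamino)prop-1-en-1-yl in place of vinyl on a carbonyl carbon. Among the compounds with values here, no measured step touches the carbonyl carbon, so nothing in the data speaks directly to this change. What the data do show is that the three changes tried so far left the number where it was. Compound 4 is therefore expected to give no step beyond the scatter, no change at the digits printed from compound 1 to compound 4 (within the scatter). Going by these compounds, the estimate for compound 4 in this assay is 3500 nM, with a range from 1200 nM to 10000 nM to reflect that this part of the structure is untested.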

Compound 4, half-maximal inhibitory concentration: 3660 nM
Estimate against measurement, compound 4: 1.0-fold (0.02 log units) below; the range from low to high includes it.
By their numbers in this assay, from the lowest: compounds 1, 4, 2 and 3 (each within the scatter of the next).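

Within the data shown here, the carbonyl end of the molecule, which no earlier step touched, now has a measured step of its own: in this assay, 3-(dimethylamino)prop-1-en-1-yl in place of vinyl on a carbonyl carbon gives (a 1.0-fold higher number from compound 1 to compound 4 (0.02 log units; within the scatter)). The entering group is larger than vinyl and adds a nitrogen and a hydrogen-bond acceptor, yet compound 4 stays within the scatter of compound 1, so changes at both ends of the shared core have now left the number within the scatter. No measurement shown here offers an explanation for this result.

The compounds shown leave open whether this position would respond to a different kind of group on the carbonyl carbon, such as ethyl, a carboxylic acid or a longer chain ending in a piperidine ring. They also leave open whether 3-(dimethylamino)prop-1-en-1-yl would give the same result when paired with the hydrazone side of compound 2 or compound 3.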